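A few compounds are considered here, and "the series" means these few. Any claim that something is new, unique, unknown or untested is made for them only; others in the source may bear on it.

Measured so far:
- compound 1, `Cc1ccnc(N2C(=O)CS[C@H]2c2cccc(C(=O)NCCCCn3cccn3)c2)c1`: "nd" (no result reported), no result reported in a functional assay on SJSA-1 cells (Homo sapiens) for inhibition, read by CCK-8 assay, with a stated time of 72 h; on this read-out lower numbers stand for stronger inhibition and higher numbers for weaker inhibition
- compound 2, `Cc1ccnc(N2C(=O)CSC2c2cccc(C(=O)NCCCCn3cccn3)c2)c1`: 33.2 nM in this assay

Compound 2 holds the only number shown in this assay; beside it stands one further entry without a single number, compound 1, and what separates that pair is the fact that one of compounds 1 and 2 is drawn with a defined configuration and the other without, at the place where they differ. Compound 3, `Cc1ccnc(N2C(=O)CS[C@@H]2c2cccc(C(=O)NCCCCn3cccn3)c2)c1`, has not yet been measured in this assay. It differs from compound 2 in this way: the two compounds have the same atoms and bonds; at least one stereo element is drawn with a configuration in one of them and without one in the other: 1 of 1 stereo elements differ; a stereocentre at a saturated ring carbon is drawn without a configuration in compound 2 and R in compound 3. Since compound 2 is drawn without a configuration at that saturated ring carbon and compound 3 with one, compound 3 may carry either more or less of what compound 2 shows, and the step in this assay could go in either direction. Compound 3 is expected to come in at about 20 nM, between 7 nM and 400 nM, which means an expected step of a 1.7-fold lower number from compound 2 to compound 3 (0.22 log units; within the scatter).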

Compound 3, half-maximal inhibitory concentration: 62.2 nM
For compound 3 the middle estimate is 3.1-fold (0.49 log units) below the measured one; the range from low to high includes it.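

With compound 3, the saturated ring carbon has its first number for a defined configuration, and in this assay the step is a 1.9-fold higher number from compound 2 to compound 3 (0.27 log units; within the scatter). On this read-out, the compound drawn as R therefore cannot be told apart from the compound drawn without a configuration at that carbon. The R form alone thus gives a result in the same range as compound 2: the fact that one of compounds 2 and 3 is drawn with a defined configuration and the other without, at the place where they differ

On these data alone, compound 1, with the other drawn configuration, has "nd" (no result reported), so the two defined forms cannot be compared with each other: the fact that compounds 1 and 3 differ only in the configuration as drawn Also open is what an amine, a carboxylic acid or a longer chain in place of the side chain on the shared core would give in this assay.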